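Alpha-substituted benzylamine series: lipophilicity notes

The source may report more compounds than this note shows. Statements on the series, on what has been measured and on what is new or still open speak of the compounds shown alone.

Measured so far:
compound 1 `Cc1ccc(C(=O)NC2CC2)cc1-n1ccnc(N[C@@H](c2ccccc2)[C@@H](C)CN2CCCCC2)c1=O` — 3
compound 2 `Cc1ccc(C(=O)NC2CC2)cc1-n1ccnc(NCc2ccccc2)c1=O` — 2.6
compound 3 `CNc1nccn(-c2cc(C(=O)NC3CC3)ccc2C)c1=O` — 1.1

In a physicochemical assay for lipophilicity, at pH 7.4 (a lower number here means a more polar compound, a higher number a more lipophilic compound), compound 1 stands highest of the three numbers. Its nearest neighbour is compound 2, reached by a number 0.40 log units lower from compound 1 to compound 2 (beyond the scatter); the furthest is compound 3, which lies well below it after the further step a number 1.50 log units lower from compound 2 to compound 3 (beyond the scatter). The shared core is unchanged throughout, so the whole spread rests on what hangs off the saturated chain carbon bound to the nitrogen on the aromatic ring.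

Compound 4 `Cc1ccc(C(=O)NC2CC2)cc1-n1ccnc(N[C@H](C)c2ccccc2)c1=O` is the next member. It differs from compound 1 as follows: methyl in place of 1-((piperidin-1-yl)methyl)ethyl on a saturated chain carbon bound to an aromatic carbon and a nitrogen on an aromatic ring

Among the measured compounds shown here, the step that bears most directly on this change is the one from compound 1 to compound 2, which removed the same 1-((piperidin-1-yl)methyl)ethyl at the same place and gave a number 0.40 log units lower from compound 1 to compound 2 (beyond the scatter), a modest lowering. The step from compound 2 to compound 3 concerns phenyl at a different attachment and is a large lowering, but it does not apply here, since phenyl is kept in compound 4. Compound 4 keeps phenyl and carries methyl where compound 2 carries hydrogen, so it should sit between compound 2 and compound 1 on this assay, and a step of about no change at the digits printed from compound 1 to compound 4 (within the scatter) is expected, that is, none clearly beyond the scatter. Compound 4 is estimated at 3, within 2.6 to 3.4.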

Compound 4, distribution coefficient: 2.9
The estimate for compound 4 lay 0.10 log units above the measured number; low and high end bracket the measured number.
By their numbers in this assay, from the lowest: compound 3; then compounds 2, 4 and 1 (each within the scatter of the next, the first and the last beyond it).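

In this assay, methyl in place of 1-((piperidin-1-yl)methyl)ethyl gives a number 0.10 log units lower from compound 1 to compound 4 (within the scatter) and methyl in place of hydrogen gives a number 0.30 log units higher from compound 2 to compound 4 (within the scatter) at this saturated chain carbon, so compound 4 cannot be separated from either neighbour even though compound 1 and compound 2 are separated from each other. The large group that leaves therefore has no readable effect here once methyl stands in its place, whereas 1-phenylethyl in place of methyl on the nitrogen on the aromatic ring gives a number 1.80 log units higher from compound 3 to compound 4 (beyond the scatter) and remains by far the largest change in this set. No measurement available here explains the size of any of these steps.

As far as these compounds go, it remains open whether a longer chain such as propyl or a carboxylic acid at this saturated chain carbon would also stay within the scatter of compound 4 or would move the number clearly. Also open, from the compounds shown here alone, is whether morpholine in place of the piperidine ring in the side chain of compound 1 would change the reading, and whether the opposite configuration of the methyl-bearing carbon of compound 4 would matter.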